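The source may hold more compounds than are shown below. What is called first, only, known or untested is meant among the compounds shown, and "the series" means these compounds.

Measured in a toxicity assay on HUVEC cells (Homo sapiens) for inhibition; a higher number here means a weaker inhibitor of growth, a lower number a stronger inhibitor of growth:
- compound 1 `Cc1nc(-c2ccccc2)c(C(=O)N2CCN(c3cccc(F)c3)CC2)o1`: 1.05 ug/mL
- compound 2 `Cc1nc(-c2ccccc2)c(C(=O)N2CCN(c3cccc(C#N)c3)CC2)o1`: 2.52 ug/mL

Of these two, compound 2 stands highest at 2.52 ug/mL. Compound 3 `Cc1nc(-c2ccccc2)c(C(=O)N2CCN(c3ccc(C)c(C)c3)CC2)o1` is not yet measured. It carries 3,4-dimethylphenyl in place of 3-cyanophenyl on an amine nitrogen in a ring.

Going by the values given here, the only measured step that bears on this change is a 2.4-fold higher number from compound 1 to compound 2 (0.38 log units; beyond the scatter), a modest one that also replaces the cyano group on the same aromatic ring. Among the compounds with values here, no measured compound carries the 3,4-dimethylphenyl group, so this guide is thin. Compound 1, which also lacks the cyano group, gives 1.05 ug/mL, so a small move towards a lower number in this assay is expected, possibly within the scatter. The expected change is a 1.6-fold lower number from compound 2 to compound 3 (0.20 log units; within the scatter). Compound 3 is estimated at 1.6 ug/mL, with an expected range of 0.6 ug/mL to 4 ug/mL.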

Compound 3, concentration for 50% growth inhibition: 3.52 ug/mL
Beside the measured number, compound 3's estimate is 2.2-fold (0.34 log units) below it, within the range that was stated.
By their numbers in this assay, from the lowest: compound 1; then compounds 2 and 3 (each within the scatter of the next).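

In this assay, exchanging 3-cyanophenyl for 3,4-dimethylphenyl on the ring amine nitrogen gives a 1.4-fold higher number from compound 2 to compound 3 (0.15 log units; within the scatter) and so opens no separation between these two groups, although the nitrile and its hydrogen-bond acceptor leave. The same exchange made against 3-fluorophenyl gives a 3.4-fold higher number from compound 1 to compound 3 (0.53 log units; beyond the scatter) and now adds a second step beyond the scatter to a 2.4-fold higher number from compound 1 to compound 2 (0.38 log units; beyond the scatter) at this position. Among the three aryl groups shown, compound 1 therefore stands apart from both compound 2 and compound 3, which cannot be ordered against each other.

Going by these compounds, whether 3-methylphenyl alone would sit with compound 1 or with compound 3 remains open, and so does the outcome for a carboxylic acid on the phenyl ring or a saturated cyclohexyl group in its place. No measurement here accounts for any of these steps.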